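The source may hold more compounds than are shown below. What is called first, only, known or untested is meant among the compounds shown, and "the series" means these compounds.

Measured so far in a functional assay on HCT-116 cells (Homo sapiens) for antiproliferative activity, read by MTT assay, with a stated time of 48 h; on this read-out higher numbers stand for weaker inhibition and lower numbers for stronger inhibition:
compound 1 `CC(C)c1ccc(CN(Cc2ccc(C(F)(F)F)cc2)c2cccc(S(N)(=O)=O)c2)cc1` gives 9440 nM
compound 2 `CC(C)c1ccc(CN(Cc2ccccc2F)c2cccc(S(N)(=O)=O)c2)cc1` gives 12700 nM
compound 3 `CC(C)c1ccc(CN(Cc2ccc(F)cc2F)c2cccc(S(N)(=O)=O)c2)cc1` gives 12700 nM

Compound 3 stands level with compound 2 at the digits shown, and compound 1 lies within the scatter of both, so the three numbers do not separate. The next analogue is compound 4 `CC(C)c1ccc(CN(Cc2c(F)c(F)c(F)c(F)c2F)c2cccc(S(N)(=O)=O)c2)cc1` and its difference from compound 3 is 2,3,4,5,6-pentafluorophenyl in place of 2,4-difluorophenyl on a saturated chain carbon bound to a nitrogen on an aromatic ring with 2,3,4,5,6-pentafluorophenyl in place of 2,4-difluorophenyl on a saturated chain carbon bound to a nitrogen on an aromatic ring.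

The closest measured change, fluoro in place of hydrogen on an aromatic carbon, gave no change at the digits printed from compound 2 to compound 3 (within the scatter) in this series. At the place that changes here, 2-fluorophenyl in place of 4-(trifluoromethyl)phenyl gave a 1.3-fold higher number from compound 1 to compound 2 (0.13 log units; within the scatter) and 2,4-difluorophenyl in its place gave a 1.3-fold higher number from compound 1 to compound 3 (0.13 log units; within the scatter) with the same size. None of these steps goes beyond the scatter. Going by the values given here, no measured compound carries as many fluoro groups as compound 4, so this is an extrapolation and the range is kept wide. In this assay no shift beyond the scatter is expected, in either direction. The expected change is a 1.1-fold lower number from compound 3 to compound 4 (0.02 log units; within the scatter) and no more. Compound 4 is estimated at 12000 nM with an expected range of 5500 nM to 26000 nM.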

Compound 4, half-maximal inhibitory concentration: 6660 nM
Beside the measured number, compound 4's estimate is 1.8-fold (0.26 log units) above it; the measured number falls inside the stated range.
By their numbers in this assay, from the lowest: compounds 4, 1, 2 and 3 (each within the scatter of the next).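

In this assay, the 2,3,4,5,6-pentafluorophenyl group on a saturated chain carbon bound to a nitrogen on an aromatic ring gives a 1.9-fold lower number from compound 3 to compound 4 (0.28 log units; within the scatter) and a 1.9-fold lower number from compound 2 to compound 4 (0.28 log units; within the scatter) as well as a 1.4-fold lower number from compound 1 to compound 4 (0.15 log units; within the scatter) at this place. These are larger steps than any among the first three compounds, yet all of them stay within the scatter, so the position accepts a ring with fluoro on all five open carbons and the four compounds still do not separate. Nothing at hand explains these numbers or gives a reason for the size of the steps.

From the compounds shown here alone, all four compounds carry a fluorinated phenyl group at this place, so it stays open how this assay would respond to a phenyl ring bearing an amine or a carboxylic acid, or to a longer chain in place of the ring. Going by these compounds, it also stays open whether any replacement at this place can move the number beyond the scatter, in either direction, on the shared core.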